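From methoxy to hydroxy on a shared core

The source may report more compounds than this note shows. Statements on the series, on what has been measured and on what is new or still open speak of the compounds shown alone.

Compound 1 `O=c1cc(-c2ccccc2)oc2cc(OCc3ccccc3)c(OCCCN3CCCC3)c(O)c12`: > 100000 nM, a limit of the assay
Compound 2 `CN1CCN(CCCCOc2c(O)cc3oc(-c4ccccc4)cc(=O)c3c2O)CC1`: 82900 nM
Compound 3 `COc1cc2oc(-c3ccccc3)cc(=O)c2c(O)c1OCCCN1CCCC1`: 6500 nM

All three results come from a functional assay on BCG823 cells (Homo sapiens) for antiproliferative activity, read by MTT assay, with a stated time of 48 h; a higher number here means a weaker inhibitor, a lower number a stronger inhibitor. Compound 3 gives the lowest number, and the nearest value, that of compound 2, lies higher by more than the scatter. The value of compound 1 is a limit, as the limit of > 100000 nM in this assay, at which 1 of the 3 values shown sits, records.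

The next compound is compound 4 `O=c1cc(-c2ccccc2)oc2cc(O)c(OCCCN3CCCC3)c(O)c12`, which has hydrogen in place of methyl on an oxygen on an aromatic ring, methoxy to hydroxy: hydrogen in place of methyl on an oxygen on an aromatic ring.

For the measured compounds named here, only one measured step changes the group on such an oxygen: an at least 15-fold lower number from compound 1 to compound 3 (1.18 log units; beyond the scatter). It is large, but it removes a phenyl and not a methyl, so it sets no size for this smaller change. It does show that this assay can respond strongly to changes on this oxygen. Compound 2, at 82900 nM, also carries a hydroxy there, but its side chain differs as well, so it offers only a loose hint of a higher number.

A moderate rise is therefore expected, and the expected step is a 2.3-fold higher number from compound 3 to compound 4 (0.36 log units; beyond the scatter). For compound 4 the estimate is 15000 nM, with an expected range from 4000 nM to 60000 nM.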

Compound 4, half-maximal inhibitory concentration: > 100000 nM
Compound 4 was reported as a limit; the forecaster's own chance of this, stated with the estimate: 8%; middle value at least 6.6-fold (0.82 log units) away from the limit.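

The small change of hydrogen in place of methyl on this oxygen proved far from moderate in this assay: an at least 15-fold higher number from compound 3 to compound 4 (1.18 log units; beyond the scatter). Together with an at least 15-fold lower number from compound 1 to compound 3 (1.18 log units; beyond the scatter), this shows that the response at this oxygen does not run in one direction, as both benzyl and hydrogen there give a weaker result than methyl, which alone among these three compounds gives a number that is not a limit. The values of compound 1 and compound 4 are both limits of the assay, and the step between them cannot be read: the limit of > 100000 nM in this assay, at which 2 of the 4 values shown sit. The remaining step, an at least 1.2-fold higher number from compound 2 to compound 4 (0.08 log units; that floor lies within the scatter), has a floor that gives no order for the two side chains.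

Whether methyl is the only group on this oxygen that gives a measurable number stays open, as ethyl, a longer chain or a chain ending in an amine are not among the compounds shown. Also open, on these data alone, is whether methyl in place of hydrogen on this oxygen would give a similar step with the 4-methylpiperazin-1-yl side chain of compound 2.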